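The compounds below may be only part of what the source reports. "The series", "measured", "known", "first", "only" and "open" are said of these compounds alone.

Compound 1 `CC(C)c1ccc(NC(=O)N[C@@H](C)c2ccccc2)cc1` and compound 2 `C[C@@H](NC(=O)Nc1ccc(Br)cc1)c1ccccc1` were both tested in an ADME assay on the whole organism with Oryza sativa as the target, tested at 10 uM; on this read-out higher numbers stand for a weaker effect at the one concentration tested and lower numbers for a stronger effect. There compound 1 gives 86%, and compound 2 gives 87%, a pair of values that fall within the usual scatter of each other, so neither can be set above the other. Going by the values given here, compound 3 `C[C@H](NC(=O)Nc1ccc(Br)cc1)c1ccccc1` has not been measured yet; the two compounds have the same atoms and bonds and differ only in configuration as drawn: 1 of 1 stereo elements differ; a stereocentre at a saturated chain carbon is drawn R in compound 2 and S in compound 3 No measured pair of compounds shows what such a change of configuration does on this read-out, so no direction can be drawn from the data. Compound 3 is therefore expected to give about 85%, within 65% to 100%, an expected step of a number 2 percentage points lower from compound 2 to compound 3 (within the scatter) that stays within the scatter.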

Compound 3, a percentage reported as activity, at one concentration (the size of the read-out at that concentration, not a potency): 96%
Beside the measured number, compound 3's estimate is 11 percentage points below it; the range from low to high includes it.
By their numbers in this assay, from the lowest: compounds 1, 2 and 3 (each within the scatter of the next).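

In this assay, going by these compounds alone, the stereocentre at the saturated chain carbon gives the first reading of a change of configuration, a number 9 percentage points higher from compound 2 to compound 3 (within the scatter), so the data show no separation between the R and S drawings at this centre. This reading is a clean one for configuration alone: the fact that compounds 2 and 3 differ only in the configuration as drawn Bromo in place of isopropyl on an aromatic carbon gives a number 10 percentage points higher from compound 1 to compound 3 (within the scatter), so that swap also shows no separation here. The compounds shown leave open whether an amine or a carboxylic acid on the aromatic ring, or a longer chain at the stereocentre, would give a step beyond the scatter.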